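The source may report more compounds than this note shows. Statements on the series, on what has been measured and on what is new or still open speak of the compounds shown alone.

Measured so far: compound 1 `CCCCCCC(=O)OCC(=O)NCc1ccc(O)c(OC)c1`, 170 nM; compound 2 `CCCCCCCC(=O)OCC(=O)NCc1ccc(O)c(OC)c1`, 40 nM.

In an assay on SH-SY5Y cells for agonist activity at transient receptor potential cation channel subfamily V member 1 (Homo sapiens), read by fluorescence and calcium flux, with a stated time of 25 min (on this read-out higher numbers stand for an effect only at larger amounts of compound and lower numbers for an effect already at smaller amounts), compound 2 gives the lower of the two numbers; the gap to the other measured compound is a 4.3-fold lower number from compound 1 to compound 2 (0.63 log units; beyond the scatter). Compound 3 `CCCCCCCCCC(=O)OCC(=O)NCc1ccc(O)c(OC)c1` differs from compound 2 by ethyl in place of hydrogen on a saturated chain carbon, seven bonds along the chain from a carbonyl carbon. Going by the values given here, the only step that bears on this change is the earlier chain extension, a 4.3-fold lower number from compound 1 to compound 2 (0.63 log units; beyond the scatter), a modest gain. Carrying the chain two bonds further is expected to give a smaller step in the same direction, a 1.6-fold lower number from compound 2 to compound 3 (0.20 log units; within the scatter), with the possibility that the gain flattens out. Compound 3 is therefore estimated at 25 nM, within 8 nM to 100 nM.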

Compound 3, half-maximal effective concentration: 200 nM
The estimate for compound 3 lay 8.0-fold (0.90 log units) below the measured number; the measured number lies above the stated range.
By their numbers in this assay, from the lowest: compound 2; then compounds 1 and 3 (each within the scatter of the next).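

Extending the chain further at this position reverses the earlier gain in this assay (a 5.0-fold higher number from compound 2 to compound 3 (0.70 log units; beyond the scatter)), so the number does not keep falling as the chain grows. Compound 3 also stands level with the shorter compound 1 (a 1.2-fold higher number from compound 1 to compound 3 (0.07 log units; within the scatter)), leaving compound 2 with the lowest number of the three. Nothing available explains this turn in direction.

Still open, on these data alone, is whether a longer chain raises the number further or loses activity altogether. As far as these compounds go, an amine or a carboxylic acid at the chain end also remains untested in these compounds.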